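The source may report more compounds than this note shows. Statements on the series, on what has been measured and on what is new or still open speak of the compounds shown alone.

In a functional assay on HCT-116 cells (Homo sapiens) for antiproliferative activity, read by MTT assay, with a stated time of 48 h (a higher number here means a weaker inhibitor, a lower number a stronger inhibitor), compound 1 (`CCCCC(CCO)n1cnc2c(Cl)nc(Cl)nc21`) gives 15500 nM and compound 2 (`CCCCCCCC(CCO)n1cnc2c(Cl)ncnc21`) gives 4160 nM, the lower of the two numbers, with a gap beyond the usual scatter. Compound 3 (`CCCCCCCC(CCO)n1cnc2c(Cl)nc(Cl)nc21`) differs from compound 2 by chloro in place of hydrogen on an aromatic carbon. Among the compounds with values here, the two measured compounds differ in more than one place, so no single-change step is available as a guide. A modest shift to a lower number in this assay is expected, possibly none beyond the scatter. The expected step is a 1.4-fold lower number from compound 2 to compound 3 (0.14 log units; within the scatter). Compound 3 is estimated at 3000 nM, within a range of 1000 nM to 9000 nM.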

Compound 3, half-maximal inhibitory concentration: 12800 nM
The estimate for compound 3 lay 4.3-fold (0.63 log units) below the measured number; the whole stated range lies below it.
By their numbers in this assay, from the lowest: compound 2; then compounds 3 and 1 (each within the scatter of the next).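

In this assay, chloro in place of hydrogen on the aromatic carbon between two ring nitrogen atoms gives a 3.1-fold higher number from compound 2 to compound 3 (0.49 log units; beyond the scatter), so with this chain, hydrogen at this position gives the lower number. With chloro held at that position, propyl in place of hydrogen on a saturated chain carbon, five bonds along the chain from an aromatic nitrogen, gives a 1.2-fold lower number from compound 1 to compound 3 (0.08 log units; within the scatter), a step within the scatter. Nothing available explains either step. Open, as far as these compounds go, are how an amine or a methoxy group at this position would compare with hydrogen, and whether the propyl step would stay within the scatter with hydrogen there.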